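The source may hold more compounds than are shown below. What is called first, only, known or untested is meant among the compounds shown, and "the series" means these compounds.

Measured in a functional assay on A549 cells (Homo sapiens) for cytotoxicity, read by MTT assay, with a stated time of 48 h; on this read-out higher numbers stand for weaker inhibition and lower numbers for stronger inhibition:
- compound 1 `COc1c(OCc2nc3ccccc3[nH]2)cc(O)c2c(=O)cc(-c3ccccc3)oc12`: > 100000 nM (a limit)
- compound 2 `COc1c(OCCCCN2CCCCC2)cc(O)c2c(=O)cc(-c3ccccc3)oc12`: 1150 nM

Among the measured compounds shown here, compound 2 holds the only actual number in this assay, and compound 1 stands at a limit. Compound 3 `COc1c(OCCCN2CCN(C)CC2)cc(O)c2c(=O)cc(-c3ccccc3)oc12` differs from compound 2 by 4-methylpiperazin-1-yl in place of (piperidin-1-yl)methyl on a saturated chain carbon, three bonds along the chain from an oxygen on an aromatic ring. For the measured compounds named here, the only measured step bearing on this, an at least 86-fold lower number from compound 1 to compound 2 (1.93 log units; beyond the scatter), is large, but it replaced a quite different group, so it shows only that this part of the molecule can matter. Since a six-membered non-aromatic ring is kept, a modest loss is expected, an estimated 2.2-fold higher number from compound 2 to compound 3 (0.34 log units; beyond the scatter). For compound 3 the estimate is 2500 nM, with an expected range of 700 nM to 12000 nM.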

Compound 3, half-maximal inhibitory concentration: 9900 nM
For compound 3 the middle estimate is 4.0-fold (0.60 log units) below the measured one, and the stated range covers the measured number.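

In this assay, the step to 4-methylpiperazin-1-yl, an 8.6-fold higher number from compound 2 to compound 3 (0.93 log units; beyond the scatter), shows that this position responds even when a six-membered non-aromatic ring is kept. The 2-(4-methylpiperazin-1-yl)ethyl group still gives an at least 10-fold lower number from compound 1 to compound 3 (1.00 log units; beyond the scatter) in place of 1H-benzimidazol-2-yl. That step is only a bound, with compound 1 standing at a limit: the limit of > 100000 nM in this assay, at which 1 of the 3 values shown sits.

Going by these compounds, whether the second ring nitrogen or its methyl goes with the step remains open. So does how an unsubstituted piperazine or a morpholine on the same chain would read in this assay here.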